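Hydroxyphenyl for thiophenyl: expected cytotoxicity of compound 4

The source may hold more compounds than are shown below. What is called first, only, known or untested is meant among the compounds shown, and "the series" means these compounds.

Measured compounds:
compound 1, `Cc1cc(-c2cccs2)cn2c(CSCCc3ccccc3)cnc12`, 20 ug/mL
compound 2, `COc1cccc(-c2cc(C)cn3c(CSCCc4ccccc4)cnc23)c1`, 100 ug/mL
compound 3, `c1ccc(CCSCc2cnc3ccc(-c4ccccc4)cn23)cc1`, 4 ug/mL

In an ADME assay on HEL cells (Homo sapiens) for cytotoxicity, with a stated time of 3 days (on this read-out higher numbers stand for lower toxicity in this test and lower numbers for higher toxicity in this test), compound 1 gives 20 ug/mL, the second highest of the three numbers. Compound 2 gives 100 ug/mL, a higher number than compound 1, and compound 3 gives 4 ug/mL, a lower one; both gaps lie beyond the scatter. Compound 4, `Cc1cc(-c2cccc(O)c2)cn2c(CSCCc3ccccc3)cnc12`, differs from compound 1 in one place: 3-hydroxyphenyl in place of thiophen-2-yl on an aromatic carbon. Going by the values given here, no measured pair shows this exact change, so its size is uncertain. Since compound 2, which carries a six-membered aromatic ring in that place, gives 100 ug/mL, the step is expected to go toward a higher number, beyond the scatter, by a 2.5-fold higher number from compound 1 to compound 4 (0.40 log units; beyond the scatter). Compound 4 is therefore estimated at 50 ug/mL, within 20 ug/mL to 100 ug/mL.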

Compound 4, minimum cytotoxic concentration: 20 ug/mL
For compound 4 the middle estimate is 2.5-fold (0.40 log units) above the measured one, and the stated range covers the measured number.
By their numbers in this assay, from the lowest: compound 3; then compounds 1 and 4 (each within the scatter of the next); then compound 2.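

In this assay, 3-hydroxyphenyl in place of thiophen-2-yl on this aromatic carbon gives no change at the digits printed from compound 1 to compound 4 (within the scatter), so exchanging these two rings does not separate the compounds on this read-out. A six-membered aromatic ring in this place therefore does not by itself bring the high number: compound 4 gives 20 ug/mL, while compound 2, with 3-methoxyphenyl there, gives 100 ug/mL. Nothing available explains this result.

Going by these compounds, whether an amine or a carboxylic acid in place of the hydroxy group on that phenyl ring would shift the number remains open.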